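Solubility of a pyridyl-amine series: a tetrazole replaces methylpiperazine

The source may report more compounds than this note shows. Statements on the series, on what has been measured and on what is new or still open speak of the compounds shown alone.

Measured compounds:
- Compound 1, `Fc1ccc(Nc2cc3[nH]c(-c4cccc(C(F)(F)F)c4)nc3cn2)nc1`, < 5000 nM
- Compound 2, `N#Cc1ccc(Nc2cc3[nH]c(-c4cccc(C(F)(F)F)c4)nc3cn2)nc1`, < 5000 nM
- Compound 3, `CN1CCN(c2ccc(Nc3cc4[nH]c(-c5cccc(C(F)(F)F)c5)nc4cn3)nc2)CC1`, 66000 nM

Within the data shown here, in a physicochemical assay for solubility, using the shake flask method, in phosphate buffer, measured as kinetic solubility, with a stated time of 20 h, at pH 6.5 (a lower number here means a less soluble compound, a higher number a more soluble compound), compound 3 stands out as the only compound with a measured number. The value of compound 1 is a limit of the assay rather than a number, and the same is true of compound 2 (the limit of < 5000 nM in this assay, at which 2 of the 3 values shown sit). Compound 4 is `FC(F)(F)c1cccc(-c2nc3cnc(Nc4ccc(-c5nnn[nH]5)cn4)cc3[nH]2)c1`; the change from compound 3 is 1H-tetrazol-5-yl in place of 4-methylpiperazin-1-yl on an aromatic carbon. Among the measured compounds shown here, two measured steps bear on it: an at least 13-fold higher number from compound 1 to compound 3 (1.12 log units; beyond the scatter) and an at least 13-fold higher number from compound 2 to compound 3 (1.12 log units; beyond the scatter), both large and both reached by introducing the group that compound 4 now loses. The reverse direction is therefore expected, a sizeable decrease in this assay, although the tetrazole differs from fluoro and cyano and the data give no direct comparison. For compound 4 a value of 10000 nM is expected, within 2000 nM to 60000 nM, meaning an estimated step of a 6.6-fold lower number from compound 3 to compound 4 (0.82 log units; beyond the scatter).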

Compound 4, solubility: < 5000 nM
Compound 4 ended at the assay's limit; the forecaster's own chance of this, stated with the estimate: 35%; at least 2.0-fold (0.30 log units) between middle value and limit.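

In this assay, 1H-tetrazol-5-yl in place of 4-methylpiperazin-1-yl gives an at least 13-fold lower number from compound 3 to compound 4 (1.12 log units; beyond the scatter), so at this position a nitrogen-rich ring with a hydrogen-bond donor does not keep the number seen with compound 3. Compound 4 gives only a limit, not a number, and it is the same limit that compounds 1 and 2 reach: the limit of < 5000 nM in this assay, at which 3 of the 4 values shown sit. The steps from compounds 1 and 2 to compound 4 cannot be read.

As far as these compounds go, it remains open how a morpholine ring, a simple amine or a carboxylic acid would behave at this position, and how compounds 1, 2 and 4 rank among themselves.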